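This account rests on a few compounds, and the source may have more. Where it says the series, first, only, none or still open, it means among the compounds named here.

Compound 1 `COc1ccc(-n2c(Nc3nc(-c4ccccc4)cs3)n[nH]c2=S)cc1` gives 100 mg/kg in a functional assay on the whole organism (strain Swiss albino) for inhibition, with Mus musculus as the target, with a stated time of 0.5 h; a higher number here means that more compound is needed for the effect, a lower number that less compound is needed.
Compound 2 `Cc1ccccc1-n1c(Nc2nc(-c3ccc([N+](=O)[O-])cc3)cs2)n[nH]c1=S` gives 100 mg/kg in this assay.
Compound 3 `COc1ccc(-n2c(Nc3nc(-c4ccc(Cl)cc4)cs3)n[nH]c2=S)cc1` gives 30 mg/kg in this assay.

Among these three numbers compound 3 stands lowest: compound 1 and compound 2 each sit at a higher number, and both gaps lie beyond the scatter. For the measured compounds named here, the only step between compounds that differ in one place, a 3.3-fold lower number from compound 1 to compound 3 (0.52 log units; beyond the scatter), concerns the chloro group on the other aromatic ring and does not touch the change considered here. Compound 4 `Cc1ccccc1-n1c(Nc2nc(-c3ccc(Cl)cc3)cs2)n[nH]c1=S` differs from compound 3 in one place: 2-methylphenyl in place of 4-methoxyphenyl on an aromatic nitrogen. Going by the values given here, no measured pair isolates this change. Compound 1, which carries the 4-methoxyphenyl group, and compound 2, which carries the 2-methylphenyl group, also differ at a second place, so their values show only that both sit at the same number. With nothing bearing directly on this change, no step beyond the scatter is expected in this assay in either direction. The estimate for compound 4 is therefore 40 mg/kg, with a range from 20 mg/kg to 100 mg/kg. The step this estimate means is expected to be a 1.3-fold higher number from compound 3 to compound 4 (0.12 log units; within the scatter).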

Compound 4, minimum effective dose: 100 mg/kg
For compound 4 the middle estimate is 2.5-fold (0.40 log units) below the measured one, within the range that was stated.
By their numbers in this assay, from the lowest: compound 3; then compounds 1, 2 and 4 (each within the scatter of the next).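

With the chloro group held constant, compound 3 and compound 4 isolate the change on the aromatic nitrogen in this assay: replacing 4-methoxyphenyl with 2-methylphenyl gives a 3.3-fold higher number from compound 3 to compound 4 (0.52 log units; beyond the scatter), so more compound is needed for the effect. With 2-methylphenyl on that nitrogen, swapping nitro for chloro gives no change at the digits printed from compound 2 to compound 4 (within the scatter), so these two groups cannot be told apart in this setting. Nothing measured here explains why the group on this nitrogen changes the dose.

The compounds shown do not separate the contribution of the methoxy group from that of the methyl group, or either of these from its place on the ring. A plain phenyl on this nitrogen, or an ethyl chain in place of the ring, would test how much of the aromatic group the dose depends on.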